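Halophenyl variation on the thioether arm of the shared core

The compounds below may be only part of what the source reports. "The series", "measured", "known", "first", "only" and "open" are said of these compounds alone.

Measured compounds and their values in a functional assay on cells (T-cell, Mus musculus, strain BALB/c) for inhibition, read by MTT assay, with stated times of 24 h and 72 h; on this read-out higher numbers stand for weaker inhibition and lower numbers for stronger inhibition:
compound 1, `COc1cc(-c2nnc(SCc3ccc(C)cc3)o2)ccc1O`: 6210 nM
compound 2, `COc1cc(-c2nnc(SCc3ccc(Cl)cc3)o2)ccc1O`: 11100 nM
compound 3, `COc1cc(-c2nnc(SCc3ccc(F)cc3F)o2)ccc1O`: 9690 nM

Compound 1 gives the lowest of the three numbers in this assay, but its nearest neighbour compound 3 and its furthest neighbour compound 2 both lie within the scatter of it, so no order among the three can be claimed. The step from compound 1 to compound 4, `COc1cc(-c2nnc(SCc3ccccc3Cl)o2)ccc1O`, is 2-chlorophenyl in place of 4-methylphenyl on a saturated chain carbon bound to a sulfur. Among the measured compounds shown here, two measured steps bear on it: a 1.8-fold higher number from compound 1 to compound 2 (0.25 log units; within the scatter), which also exchanges methyl for chloro on the aromatic ring, and a 1.6-fold higher number from compound 1 to compound 3 (0.19 log units; within the scatter), which also replaces the 4-methylphenyl by a halogenated phenyl. Both are small and both point to a higher number, and a 1.1-fold lower number from compound 2 to compound 3 (0.06 log units; within the scatter) shows that the two halogenated arms give much the same result. For compound 4 a small shift toward a higher number, not beyond the scatter, is therefore expected, a 1.4-fold higher number from compound 1 to compound 4 (0.14 log units; within the scatter). The estimate for compound 4 in this assay is 8500 nM, with a range from 4000 nM to 18000 nM.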

Compound 4, half-maximal inhibitory concentration: 8430 nM
Compound 4: the middle estimate sits 1.0-fold (0.00 log units) above what was measured; the range from low to high includes it.
By their numbers in this assay, from the lowest: compounds 1, 4, 3 and 2 (each within the scatter of the next).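

In this assay, 2-chlorophenyl in place of 4-chlorophenyl gives a 1.3-fold lower number from compound 2 to compound 4 (0.12 log units; within the scatter), so this change of chlorinated arm on the saturated chain carbon bound to a sulfur shows no readable effect. The same holds for 2-chlorophenyl in place of 2,4-difluorophenyl, with a 1.1-fold lower number from compound 3 to compound 4 (0.06 log units; within the scatter), and for 2-chlorophenyl in place of 4-methylphenyl, with a 1.4-fold higher number from compound 1 to compound 4 (0.13 log units; within the scatter), which leaves all four arms within the scatter of one another and this position without a readable preference among them. No measurement shown accounts for this flat result.

From the compounds shown here alone, whether a phenyl arm carrying an amine or a carboxylic acid, or a longer chain in place of these phenyl arms, would shift the number beyond the scatter stays open. Going by these compounds, all four compounds keep the shared core, so the effect of changes to it also stays open.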